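Benzyl Ester and Thiourea Combined on a Shared Core

The compounds below may be only part of what the source reports. "The series", "measured", "known", "first", "only" and "open" are said of these compounds alone.

Measured compounds:
compound 1, `CC1=C(C(=O)OCc2ccccc2)C(c2ccoc2)NC(=O)N1`, 41%
compound 2, `CC1=C(C(=O)OCc2ccccc2)C(c2cccs2)NC(=O)N1`, 45%
compound 3, `CCCOC(=O)C1=C(C)NC(=S)NC1c1ccco1`, 1%

In an assay on membranes from CHO cells for displacement of a labelled ligand from adenosine receptor A1 (Homo sapiens), read by scintillation counting, with a stated time of 60 min, tested at 1 uM (a lower number here means less inhibition, a higher number more inhibition at the concentration tested (going by the name of the read-out)), compound 3 gives 1%, the lowest of the three numbers; compound 1 stands above it by a gap beyond the scatter, and compound 2 stands further above. For the measured compounds named here, the one single-point step among the measured pairs, a number 4 percentage points higher from compound 1 to compound 2 (within the scatter), lies within the scatter and concerns the group on the saturated ring carbon, not the ester.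

Compound 4, `CC1=C(C(=O)OCc2ccccc2)C(c2ccco2)NC(=S)N1`, is not yet measured. It differs from compound 3 by phenyl in place of ethyl on a saturated chain carbon bound to an oxygen next to a carbonyl group. Going by the values given here, no measured pair isolates this change: compound 1 and compound 2 carry the benzyl ester, but each differs from compound 3 in more than one place, so their gap to compound 3 cannot be assigned to the ester alone. The direction of that gap is the only hint available.

On that weak basis the step of a number 19 percentage points higher from compound 3 to compound 4 (beyond the scatter) is expected to be upward, though its size is uncertain. Compound 4 is estimated at 20%, with a range from 0% to 48%, because compound 3 sits at 1% and the benzyl-bearing compounds sit well above it.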

Compound 4, a percentage reported as inhibition, at one concentration (the size of the read-out at that concentration, not a potency): 32%
Estimate against measurement, compound 4: 12 percentage points below; measured number inside the range.
By their numbers in this assay, from the lowest: compound 3; then compounds 4, 1 and 2 (each within the scatter of the next, the first and the last beyond it).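

In this assay, for the compounds shown here, the step of a number 31 percentage points higher from compound 3 to compound 4 (beyond the scatter) gives the first direct reading of this position, with phenyl in place of ethyl on a saturated chain carbon bound to an oxygen next to a carbonyl group and the rest of the molecule unchanged. Compound 1 and compound 2 also carry the benzyl ester, but each differs from compound 3 in more than one place, whereas here the propyl to benzyl change stands alone and is large, so this position clearly responds to the group it carries. The data hold nothing that explains the rise, and it remains an observation without a known cause.

The compounds shown leave open whether the rise depends on the aromatic ring itself or on the larger group in general, a question that cyclohexyl in place of phenyl, or a longer chain such as hexyl in place of ethyl, would address. Going by these compounds alone, they also contain no pair that isolates the thiocarbonyl against the carbonyl of the shared core, so the share of that change in the values of the benzyl esters stays open.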